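Bis-trifluoromethyl hydrazone on the monofluorobenzoyl series

The source may report more compounds than this note shows. Statements on the series, on what has been measured and on what is new or still open speak of the compounds shown alone.

Measured so far:
compound 1 `CN(C(=O)NC(=O)c1c(F)cccc1F)c1nc(C(F)(F)F)c(C(=O)N/N=C/c2cc(C(F)(F)F)cc(C(F)(F)F)c2)s1` — 17.3 ug/mL
compound 2 `CN(C(=O)NC(=O)c1ccccc1F)c1nc(C(F)(F)F)c(C(=O)N/N=C/c2cccc(C(F)(F)F)c2)s1` — 19.5 ug/mL

In a functional assay on A549 cells (Homo sapiens) for inhibition, read by MTT assay, with a stated time of 72 h (on this read-out higher numbers stand for weaker inhibition and lower numbers for stronger inhibition), compound 2 gives 19.5 ug/mL, the higher of the two numbers; compound 1 gives 17.3 ug/mL, and the gap between the two lies within the scatter. Compound 3 `CN(C(=O)NC(=O)c1ccccc1F)c1nc(C(F)(F)F)c(C(=O)N/N=C/c2cc(C(F)(F)F)cc(C(F)(F)F)c2)s1` differs from compound 2 by trifluoromethyl in place of hydrogen on an aromatic carbon. Compound 1 already carries that same group together with a different benzoyl part and sits at the same level as compound 2, so no step beyond the scatter is expected from compound 2 to compound 3, a 1.1-fold lower number from compound 2 to compound 3 (0.03 log units; within the scatter). Compound 3 is therefore estimated at 18 ug/mL, within 9 ug/mL to 36 ug/mL.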

Compound 3, half-maximal inhibitory concentration: 5.43 ug/mL
For compound 3 the middle estimate is 3.3-fold (0.52 log units) above the measured one, outside the stated range (below it).
By their numbers in this assay, from the lowest: compound 3; then compounds 1 and 2 (each within the scatter of the next).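

In this assay, trifluoromethyl in place of hydrogen on an aromatic carbon, meta to a trifluoromethyl group, gives a 3.6-fold lower number from compound 2 to compound 3 (0.56 log units; beyond the scatter), so this position is sensitive to substitution when the benzoyl part carries a single fluoro. Hydrogen in place of fluoro on the benzoyl part gives a 3.2-fold lower number from compound 1 to compound 3 (0.50 log units; beyond the scatter), so that site also matters when the second trifluoromethyl is present. Nothing available explains either step.

As far as these compounds go, whether a chlorine, a methoxy group or an amine at this position would give a similar step remains open.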